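This account rests on a few compounds, and the source may have more. Where it says the series, first, only, none or still open, it means among the compounds named here.

In a functional assay on MCF7 cells (Homo sapiens) for cytotoxicity, read by MTT assay, with a stated time of 72 h (on this read-out higher numbers stand for weaker inhibition and lower numbers for stronger inhibition), three compounds are measured so far:
- compound 1 `CNC(=O)c1cc(Oc2ccc(NC(=O)c3cc(-c4ccc(Br)cc4)ncn3)cc2)ccn1` gives > 100000 nM (a limit)
- compound 2 `CNC(=O)c1cc(Oc2ccc(NC(=O)c3nccc(-c4ccc([N+](=O)[O-])cc4)n3)cc2)ccn1` gives > 100000 nM (a limit)
- compound 3 `CNC(=O)c1cc(Oc2ccc(NC(=O)c3nccc(-c4cccc(Cl)c4)n3)cc2)ccn1` gives > 100000 nM (a limit)

Compound 3 stands at > 100000 nM as a limit and not as a number. Among the compounds with values here, the picture for the whole set is the limit of > 100000 nM in this assay, at which 3 of the 3 values shown sit, and so no compound can be ranked. The change to compound 4 `CNC(=O)c1cc(Oc2ccc(NC(=O)c3nccc(-c4ccc(OC)cc4)n3)cc2)ccn1` is 4-methoxyphenyl in place of 3-chlorophenyl on an aromatic carbon and puts 4-methoxyphenyl in place of 3-chlorophenyl on an aromatic carbon. Within the data shown here, the one measured change at this place is a step that the two limits leave unreadable from compound 2 to compound 3 and it gives no size or direction to carry over. The expected change is a number no higher from compound 3 to compound 4 (the limit leaves the size open) and no readable step is foreseen. For compound 4 the estimate is 100000 nM with an expected range from 30000 nM to 200000 nM and a report as a limit is likely.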

Compound 4, half-maximal inhibitory concentration: 35200 nM
For compound 4 the middle estimate is 2.8-fold (0.45 log units) above the measured one; low and high end bracket the measured number.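

In this assay, 4-methoxyphenyl in place of 3-chlorophenyl on this aromatic carbon gives an at least 2.8-fold lower number from compound 3 to compound 4 (0.45 log units; beyond the scatter), and methoxy in place of nitro gives an at least 2.8-fold lower number from compound 2 to compound 4 (0.45 log units; beyond the scatter). Within the data shown here, the group at this place can therefore bring the read-out below the limit of the assay, and compound 4 is the first compound here that carries a true number. The full size of both steps stays open because their starting compounds carry only limits: the limit of > 100000 nM in this assay, at which 3 of the 4 values shown sit.

Whether the methoxy needs this place on the phenyl ring remains open, since 3-methoxyphenyl is not among the compounds shown. Also open, going by these compounds, is what an amine or a carboxylic acid would give in place of the methoxy.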